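Fluorine for methylsulfanyl on the pendant aryl ring

This account rests on a few compounds, and the source may have more. Where it says the series, first, only, none or still open, it means among the compounds named here.

Compound 1 `CCC1=C(O)c2c(oc(-c3ccc(CC)cc3)cc2=O)C(CC)(CC)C1=O` gives 0.07 uM in a functional assay on KBVIN cells (Homo sapiens) for antiproliferative activity, read by sulforhodamine B assay, with a stated time of 3 days; a lower number here means that less compound is needed, a higher number that more compound is needed for the effect. Compound 2 `CCCCc1ccc(-c2cc(=O)c3c(o2)C(CC)(CC)C(=O)C(CC)=C3O)cc1` gives 37 uM, and compound 3 `CCC1=C(O)c2c(oc(-c3ccc(SC)cc3)cc2=O)C(CC)(CC)C1=O` gives 1.38 uM, both in this assay. Compound 3 thus holds the second highest of the three numbers; its nearest neighbour is compound 1 and its furthest is compound 2, and the widest gap in the set is a 530-fold higher number from compound 1 to compound 2 (2.72 log units; beyond the scatter).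

Compound 4 `CCC1=C(O)c2c(oc(-c3ccccc3F)cc2=O)C(CC)(CC)C1=O` differs from compound 3 in one place: 2-fluorophenyl in place of 4-(methylsulfanyl)phenyl on an aromatic carbon. Among the measured compounds shown here, no measured step exchanges one aryl group for another carrying a fluorine, so none bears on it directly. The two steps that end at compound 3 are the closest guides, since each also exchanges a group on an aromatic carbon: a 20-fold higher number from compound 1 to compound 3 (1.29 log units; beyond the scatter) and a 27-fold lower number from compound 2 to compound 3 (1.43 log units; beyond the scatter). Both are large and run in opposite directions, showing only that this part of the molecule moves the number strongly, without fixing which way the present change will go. Against that spread a modest shift is expected, and the estimated step is a 1.4-fold lower number from compound 3 to compound 4 (0.14 log units; within the scatter). For compound 4 the expected value in this assay is 1 uM, with a range from 0.1 uM to 10 uM.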

Compound 4, concentration for half-maximal effect: 3.93 uM
Compound 4: middle estimate off by 3.9-fold (0.59 log units), on the low side; the measured number falls inside the stated range.
By their numbers in this assay, from the lowest: compound 1; then compound 3; then compound 4; then compound 2.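

In this assay, replacing the 4-substituted phenyl with 2-fluorophenyl on this aromatic carbon next to the ring oxygen gives a 2.8-fold higher number from compound 3 to compound 4 (0.45 log units; beyond the scatter) and a 56-fold higher number from compound 1 to compound 4 (1.75 log units; beyond the scatter), so a fluorinated aryl group is tolerated here but does not match 4-ethylphenyl. The change from 4-(methylsulfanyl)phenyl is modest beside the large steps among the 4-substituted compounds, and the new order leaves compound 1 with the lowest number of the four, while compound 4 stands at 3.93 uM and compound 2, with the higher number of these two, stands at 37 uM in the same assay. Nothing available on these compounds accounts for these shifts, and the size of the steps is all that can be stated.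

The step from compound 3 to compound 4 alters both the substituent and where it sits on the phenyl ring, so the contribution of each remains unresolved; a fluorine in the place held by ethyl in compound 1, or a plain phenyl, would separate them. Also open, going by these compounds, is how the number responds to a substituent of another kind on the pendant ring, such as an amine or a carboxylic acid.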